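The compounds below may be only part of what the source reports. "The series", "measured", "known", "first", "only" and "open" are said of these compounds alone.

Compound 1 `N#Cc1c(-c2ccc(O)cc2)c(C#N)c(=O)n(/N=C/c2cn(-c3ccccc3)nc2-c2ccccc2)c1N` was tested in an ADME assay on HeLa cells (Homo sapiens) for cytotoxicity, read by MTT assay; on this read-out lower numbers stand for stronger inhibition and higher numbers for weaker inhibition. In that test compound 1 gives only the assay limit of > 200 ug/mL. Compound 2 `N#Cc1c(-c2ccc([N+](=O)[O-])cc2)c(C#N)c(=O)n(/N=C/c2cn(-c3ccccc3)nc2-c2ccccc2)c1N` likewise gives only the assay limit of > 200 ug/mL. The move a step that the two limits leave unreadable from compound 1 to compound 2 therefore cannot be sized, since both values rest at the limit of > 200 ug/mL in this assay, at which 2 of the 2 values shown sit. Compound 3 `N#Cc1c(-c2ccc(C(F)(F)F)cc2)c(C#N)c(=O)n(/N=C/c2cn(-c3ccccc3)nc2-c2ccccc2)c1N` carries trifluoromethyl in place of nitro on an aromatic carbon. Within the data shown here, no measured step speaks to this change, so no shift beyond the usual scatter is expected, namely a step that the limit leaves unreadable from compound 2 to compound 3. Compound 3 is estimated at 250 ug/mL, with a range from 120 ug/mL to 600 ug/mL, and most likely it too will be reported only as a limit.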

Compound 3, half-maximal inhibitory concentration: > 200 ug/mL
Compound 3: no number, only a limit; the forecaster's own chance of this, stated with the estimate: 80%; the middle value lies beyond the limit too.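

Among these compounds, no step among compound 1, compound 2 and compound 3 can be read, since all three give the same assay limit rather than a number: the limit of > 200 ug/mL in this assay, at which 3 of the 3 values shown sit.

The compounds shown leave open whether hydroxy, nitro and trifluoromethyl differ at all in this assay.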